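Swapping Amino for Methoxy: What to Expect for Compound 3

The source may hold more compounds than are shown below. What is called first, only, known or untested is meant among the compounds shown, and "the series" means these compounds.

Among the measured compounds shown here, compound 2 `COc1cc(-c2cc(/C=C/C(=O)c3ccc(N)cc3)[nH]n2)cc(OC)c1OC` gives -64% in a functional assay on RXF 393 cells (Homo sapiens) for cytotoxicity, read by sulforhodamine B assay, with a stated time of 48 h, tested at 10 uM (a lower number here means a stronger effect, a higher number a weaker effect of the compound at the concentration tested), the lowest of the two numbers measured so far. Compound 1 `COc1ccc(-c2cc(/C=C/C(=O)c3ccc(N)cc3)[nH]n2)cc1` gives -47% in this assay, a gap that lies beyond the usual scatter. Compound 3 `COc1ccc(C(=O)/C=C/c2cc(-c3cc(OC)c(OC)c(OC)c3)n[nH]2)cc1` has not been measured yet. It differs from compound 2 in one place: methoxy in place of amino on an aromatic carbon. For the measured compounds named here, no measured pair shows this same change, so its effect is unknown, and a step within the scatter, in no particular direction, is expected. Compound 3 is therefore estimated at -55% in this assay, between -85% and -25%. The expected step is a number 9 percentage points higher from compound 2 to compound 3 (within the scatter).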

Compound 3, a percentage reported as activity, at one concentration (the size of the read-out at that concentration, not a potency): -97%
Estimate against measurement, compound 3: 42 percentage points above; the whole stated range lies above it.
By their numbers in this assay, from the lowest: compound 3; then compound 2; then compound 1.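

In this assay, methoxy in place of amino on this aromatic carbon gives a number 33 percentage points lower from compound 2 to compound 3 (beyond the scatter) and shows that the read-out responds strongly to the group at this place. The amino group is therefore not required here for a strong effect, since methoxy, with no hydrogen-bond donor, goes further. Nothing available explains the size of this step. On these data alone, whether a hydroxyl group, an ethoxy group or plain hydrogen at this place would keep the effect stays open. So does whether the same swap gives a similar step on the core of compound 1.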